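Amino acid variation on the quinone nitrogen of compound 1

The source may hold more compounds than are shown below. What is called first, only, known or untested is meant among the compounds shown, and "the series" means these compounds.

Compound 1 `CC1=CCC[C@H]2[C@](C)(CC3=CC(=O)C=C(N[C@@H](C(=O)O)C(C)C)C3=O)[C@@H](C)CC[C@]12C` is the reference point of this small set. In a functional assay on MDA-MB-453 cells (Homo sapiens) for cytotoxicity, read by MTT assay, with a stated time of 72 h (on this read-out lower numbers stand for stronger inhibition and higher numbers for weaker inhibition), compound 1 gives 8010 nM, the lowest of the three numbers available. Compound 2 `C[C@H](NC1=CC(=O)C=C(C(C)(C)C)C1=O)C(=O)O` gives 112000 nM and compound 3 `CC(C)(C)C1=CC(=O)C=C(NCCC(=O)O)C1=O` gives 94100 nM in this assay; both stand well beyond the scatter from compound 1.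

Among the measured compounds shown here, the only measured step within the set, a 1.2-fold lower number from compound 2 to compound 3 (0.08 log units; within the scatter), concerns a rearrangement of the carboxy-bearing chain on the amine nitrogen and lies within the scatter, so it offers no sign that the exact shape of this chain moves the number much. For the measured compounds named here, no measured pair shows the change now in question, 1-carboxy-2-methylpropyl to 1-carboxyethyl.

Compound 4 `CC1=CCC[C@H]2[C@](C)(CC3=CC(=O)C=C(N[C@@H](C)C(=O)O)C3=O)[C@@H](C)CC[C@]12C` differs from compound 1 as 1-carboxyethyl in place of 1-carboxy-2-methylpropyl on an amine nitrogen

Given that the one change at the amine nitrogen measured so far stayed within the scatter, compound 4 is expected to move from compound 1 by no more than the scatter, a 1.2-fold higher number from compound 1 to compound 4 (0.10 log units; within the scatter), in this assay. Compound 4 is therefore estimated at 10000 nM, with a plausible range from 4000 nM to 25000 nM.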

Compound 4, half-maximal inhibitory concentration: 14700 nM
Estimate against measurement, compound 4: 1.5-fold (0.17 log units) below, and the stated range covers the measured number.
By their numbers in this assay, from the lowest: compounds 1 and 4 (each within the scatter of the next); then compounds 3 and 2 (each within the scatter of the next).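

Among the compounds shown here, on the core of compound 1, replacing 1-carboxy-2-methylpropyl with 1-carboxyethyl on the amine nitrogen gives the first measured change of this chain with that core in place, and in this assay it stays within the scatter (a 1.8-fold higher number from compound 1 to compound 4 (0.26 log units; within the scatter)). Together with the earlier step between compounds 2 and 3, this makes two changes at this nitrogen, and neither moves the number beyond the scatter, although this covers only these four compounds. With 1-carboxyethyl held constant and the difference lying away from this chain, compound 4 gives 14700 nM and compound 2 gives 112000 nM, so the printed values place the larger gap in the set at that other site, while no data on hand offer an explanation for either result.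

Still open, on these data alone, is whether the carboxylic acid itself matters, as a methyl ester or a primary amide in its place would test this on the shared core. A longer chain, a benzyl side chain, a side chain ending in an amine and the opposite configuration at the stereocentre of the chain also remain unexplored among the compounds shown, so the tolerance seen here extends only to 1-carboxy-2-methylpropyl and 1-carboxyethyl on this core.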